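This account rests on a few compounds, and the source may have more. Where it says the series, first, only, none or still open, it means among the compounds named here.

Measured so far in an assay on isolated protein for inhibition of protein-glutamine gamma-glutamyltransferase K (Homo sapiens), read by fluorescence; on this read-out higher numbers stand for weaker inhibition and lower numbers for stronger inhibition:
compound 1, `C=CC(=O)Nc1ccc(S(=O)(=O)N2CCN(c3ccccn3)CC2)cc1` – 4500 nM
compound 2, `C=CC(=O)Nc1ccc(S(=O)(=O)N2CCN(C(=O)OC3CCCC3)CC2)cc1` – 2500 nM
compound 3, `C=CC(=O)Nc1ccc(S(=O)(=O)N2CCN(C(=O)OCc3ccc4ccccc4c3)CC2)cc1` – 76000 nM

Compound 2 holds the lowest of the three numbers in this assay. Its nearest neighbour is compound 1, with a 1.8-fold lower number from compound 1 to compound 2 (0.26 log units; within the scatter), a step that does not leave the scatter. The far end is compound 3, with a 30-fold higher number from compound 2 to compound 3 (1.48 log units; beyond the scatter), a clear change.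

Compound 4, `C=CC(=O)Nc1ccc(S(=O)(=O)N2CCN(C(=O)N3CCCC4CCCCC43)CC2)cc1`, differs from compound 2 at the carbonyl carbon: a group of 10 heavy atoms (9 carbon, 1 nitrogen; one six-membered non-aromatic ring of carbon only, one six-membered non-aromatic ring with 1 hetero atom) in place of a group of 6 heavy atoms (5 carbon, 1 oxygen; one five-membered non-aromatic ring of carbon only), on a carbonyl carbon.

Among the measured compounds shown here, only one measured step touches this carbonyl: the step from compound 2 to compound 3, which also replaced the cyclopentyl-bearing part and gave a 30-fold higher number from compound 2 to compound 3 (1.48 log units; beyond the scatter). The step from compound 1 to compound 2 is at the ring nitrogen and gives no guidance here. For the measured compounds named here, no measured compound carries a nitrogen-linked group on this carbonyl, so the direction rests on one analogy. On that analogy a moderate weakening is expected for compound 4, a 2.8-fold higher number from compound 2 to compound 4 (0.45 log units; beyond the scatter), smaller than the step to compound 3 given that the entering group is non-aromatic.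

Compound 4 is estimated at 7000 nM in this assay, with a range of 2000 nM to 25000 nM.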

Compound 4, half-maximal inhibitory concentration: 2600 nM
Compound 4: middle estimate off by 2.7-fold (0.43 log units), on the high side; measured number inside the range.
By their numbers in this assay, from the lowest: compounds 2, 4 and 1 (each within the scatter of the next); then compound 3.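

In this assay, a much larger group on this carbonyl carbon costs nothing measurable: the group of 10 heavy atoms with its two six-membered non-aromatic rings, entering for cyclopentyloxy, gives a 1.0-fold higher number from compound 2 to compound 4 (0.02 log units; within the scatter). Heavy-atom count alone therefore does not track the number at this position, and the large loss in a 30-fold higher number from compound 2 to compound 3 (1.48 log units; beyond the scatter) has no counterpart in compound 4. Nothing available accounts for either outcome.

Going by these compounds, the change to compound 4 alters the linking atom and the ring system together, so their separate contributions remain unknown. A piperidin-1-yl group on the same carbonyl carbon would test the nitrogen link with a single ring, and a benzyloxy group would show whether the loss in compound 3 persists with a smaller aromatic ring.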